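A few compounds are considered here, and "the series" means these few. Any claim that something is new, unique, unknown or untested is made for them only; others in the source may bear on it.

Of the compounds shown here, three have been tested so far in an assay on HEK293 cells for inhibition of Lysophosphatidylserine lipase ABHD12 (Homo sapiens), read by scintillation counting, with stated times of 30 min and 5 min; a higher number here means a weaker inhibitor, a lower number a stronger inhibitor. Compound 1 `Cc1c(Br)cc(C(=O)NC2CCNCC2)c(=O)n1Cc1ccc(F)cc1` reaches only the limit of the assay, > 10000 nM. Compound 2 `Cc1ccc(C(=O)NC2CCCCCC2)c(=O)n1Cc1ccc(F)cc1` likewise gives only a limit, > 10000 nM. Compound 3 `Cc1ccc(C(=O)NC2CCCCCC2)c(OCc2ccc(F)cc2)n1` also stops at a limit, > 10000 nM. Among the measured compounds shown here, all three therefore sit at the limit of > 10000 nM in this assay, at which 3 of the 3 values shown sit, and no measured step between any two of them can be sized. Compound 4 `Cc1nc(OCc2ccc(F)cc2)c(C(=O)NC2CCCCCC2)cc1Br` differs from compound 3 in one place: bromo in place of hydrogen on an aromatic carbon. Since compound 3 stands only at a limit, the step expected in this assay is a step that the limit leaves unreadable from compound 3 to compound 4, that is, none beyond the scatter. Compound 4 is thus expected to give about 15000 nM in this assay, within a range from 4000 nM to 60000 nM, and most likely again only as a limit.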

Compound 4, half-maximal inhibitory concentration: 2100 nM
For compound 4 the middle estimate is 7.1-fold (0.85 log units) above the measured one; the whole stated range lies above it.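

On this aromatic carbon, ortho to a methyl group and para to the (4-fluorobenzyl)oxy group, bromo in place of hydrogen gives an at least 4.7-fold lower number from compound 3 to compound 4 (0.67 log units; beyond the scatter) in this assay. Among the compounds shown here, this single added atom yields the first measurable value, so this position can change the result in this assay. Compound 4 is the only compound shown that gives a number instead of a limit: the limit of > 10000 nM in this assay, at which 3 of the 4 values shown sit.

On these data alone, whether chloro, nitrile or a methyl group on this same carbon would give a similar step remains open. So does whether bromo would have the same effect with an amide group other than the one shared by compound 3 and compound 4.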